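A few compounds are considered here, and "the series" means these few. Any claim that something is new, unique, unknown or untested is made for them only; others in the source may bear on it.

Measured so far:

compound 1, `N#CC1=C(N)Oc2c(c3nc4ccccc4nc3c3ccccc23)C12C(=O)N(Cc1cnnn1-c1ccccc1Cl)c1ccccc12` — in a functional assay on MCF7 cells (Homo sapiens) for antiproliferative activity, read by MTT assay, with a stated time of 48 h (a lower number here means a stronger inhibitor, a higher number a weaker inhibitor), compound 1 gives > 50000 nM, which is a limit of the assay.
compound 2, `N#CC1=C(N)Oc2c(c3nc4ccccc4nc3c3ccccc23)C12C(=O)N(Cc1cnnn1-c1ccc(N)cc1)c1ccccc12` — in this assay compound 2 gives > 50000 nM, which is a limit of the assay.

Compound 2 therefore stands at the limit of the assay and nowhere more exact; both values shown sit at that same limit (the limit of > 50000 nM in this assay, at which 2 of the 2 values shown sit). The step from compound 1 to compound 2, which exchanges the group on the aromatic nitrogen, reads as a step that the two limits leave unreadable from compound 1 to compound 2, so its size cannot be read from the two values.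

Compound 3, `Cc1ccc(-n2nncc2CN2C(=O)C3(C(C#N)=C(N)Oc4c3c3nc5ccccc5nc3c3ccccc43)c3ccccc32)c(C)c1`, is related to compound 2 by 2,4-dimethylphenyl in place of 4-aminophenyl on an aromatic nitrogen. Going by the values given here, the one measured step that bears on this place, from compound 1 to compound 2, is unreadable, so it offers no size and no direction for the step in this assay. The expectation for compound 3 therefore rests on the two limits alone, and the most likely outcome is estimated to be a further limit rather than a number, a step that the limit leaves unreadable from compound 2 to compound 3. Compound 3 is estimated at 60000 nM, with a range from 15000 nM to 200000 nM.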

Compound 3, half-maximal inhibitory concentration: > 50000 nM
Compound 3 was reported as a limit (the forecaster's own chance of this, stated with the estimate: 80%); the middle value lies beyond the limit too.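

In this assay no new step can be read among compound 1, compound 2 and compound 3, since all three stand at one limit of the assay: the limit of > 50000 nM in this assay, at which 3 of the 3 values shown sit. The compounds shown leave open how far each of the three lies beyond this limit, and whether any other group at this place would give a readable value.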